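A few compounds are considered here, and "the series" means these few. Any claim that something is new, unique, unknown or untested is made for them only; others in the source may bear on it.

Measured so far in a functional assay on A549 cells (Homo sapiens) for cytotoxicity, read by MTT assay, with a stated time of 72 h; on this read-out higher numbers stand for weaker inhibition and lower numbers for stronger inhibition:
- compound 1 `O=C(N/N=C/c1cccc(Br)c1)Nc1cc2c(Nc3ccc(F)c(Cl)c3)ncnc2cc1O[C@H]1CCOC1`: 10700 nM
- compound 2 `COc1cc2ncnc(Nc3ccc(F)c(Cl)c3)c2cc1NC(=O)N/N=C/c1ccc(F)cc1`: 26600 nM

Of these two numbers, the higher belongs to compound 2 at 26600 nM, which makes it the weaker of the pair, and the gap to compound 1 lies beyond the usual scatter. Among the measured compounds shown here, no two measured compounds differ in one place only, so no measured step can guide the next prediction.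

Compound 3 `COc1cc2ncnc(Nc3ccc(F)c(Cl)c3)c2cc1NC(=O)N/N=C/c1cccc(Br)c1` is still unmeasured. Going to it from compound 2 brings this change: 3-bromophenyl in place of 4-fluorophenyl on a carbon with a double bond to nitrogen. In words, 3-bromophenyl stands in place of 4-fluorophenyl on a carbon with a double bond to nitrogen.

For the measured compounds named here, the one measured compound carrying 3-bromophenyl, compound 1, gives 10700 nM, a weak hint toward lower numbers. In this assay, the expected change is small and probably within the scatter: a 1.6-fold lower number from compound 2 to compound 3 (0.19 log units; within the scatter). For compound 3 the estimated value is 17000 nM, with an expected range of 7000 nM to 40000 nM.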

Compound 3, half-maximal inhibitory concentration: 28100 nM
Compound 3: the middle estimate sits 1.7-fold (0.22 log units) below what was measured; the measured number falls inside the stated range.
By their numbers in this assay, from the lowest: compound 1; then compounds 2 and 3 (each within the scatter of the next).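

In this assay the swap of 4-fluorophenyl for 3-bromophenyl on a carbon with a double bond to nitrogen makes no real difference (a 1.1-fold higher number from compound 2 to compound 3 (0.02 log units; within the scatter)), so on the shared core bearing methyl on the ring oxygen, these two groups cannot be told apart. The other site does matter: with methyl in place of oxolan-3-yl on an oxygen on an aromatic ring, the number shifts modestly but beyond the scatter (a 2.6-fold higher number from compound 1 to compound 3 (0.42 log units; beyond the scatter)), so the lower number of compound 1 goes with oxolan-3-yl rather than with 3-bromophenyl. No measurement here explains either result.

From the compounds shown here alone, whether 4-fluorophenyl would gain as much alongside oxolan-3-yl remains open. So does the effect of an unsubstituted phenyl on the carbon, or of a longer chain ending in an amine on the oxygen.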